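Three Limits in Hand, One Acid Analogue to Come

The source may hold more compounds than are shown below. What is called first, only, known or untested is meant among the compounds shown, and "the series" means these compounds.

Compound 1 `C[C@@]12CCCC[C@H]1CC=C(O)C2=O` gives > 2000000 nM in an ADME assay on NIH3T3 cells (Mus musculus) for antiproliferative activity, read by sulforhodamine B assay, with a stated time of 48 h; a higher number here means a weaker inhibitor, a lower number a stronger inhibitor; this value is a limit of the assay, not a number.
Compound 2 `C[C@H]1N=C2C[C@H]3C[C@H](C3(C)C)[C@@]2(C)OC1=O` gives > 1800000 nM in this assay; again only a limit.
Compound 3 `CC(C)(C)OC(=O)NCCC[C@@H]1N=C2C[C@@H]3C[C@@H](C3(C)C)[C@]2(C)OC1=O` gives > 1200000 nM in this assay; also a limit.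

Compound 2 stands at the limit of > 1800000 nM in this assay, at which 1 of the 3 values shown sits. For the measured compounds named here, since none of the three values is a number, no step between measured compounds can be sized, and no pattern can be drawn from them. Compound 4 `CC1(C)[C@H]2CC3=N[C@H](CCC(=O)O)C(=O)O[C@]3(C)[C@@H]1C2` differs from compound 2 by carboxymethyl in place of hydrogen on a saturated chain carbon bound to a saturated ring carbon. With only limits to go on, the expected step is a step that the limit leaves unreadable from compound 2 to compound 4, which is taken as none beyond the scatter. Compound 4 is therefore estimated at 2000000 nM, within a range from 400000 nM to 10000000 nM, and most probably this assay will once more report only a limit.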

Compound 4, half-maximal inhibitory concentration: > 1200000 nM
Compound 4: no number, only a limit; the forecaster's own chance of this, stated with the estimate: 85%; the middle value does not contradict the limit.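

For the compounds shown here, compound 2 and compound 4 each give only a limit, and no step between them can be read. The compounds shown leave open the actual half-maximal inhibitory concentration of any of them in this assay.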